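Swapping methyl for methylsulfanyl on a weakly cytotoxic series

The source may hold more compounds than are shown below. What is called first, only, known or untested is meant among the compounds shown, and "the series" means these compounds.

Of the compounds shown here, two sharing one core have been measured in a functional assay on SK-OV-3 cells (Homo sapiens) for cytotoxicity; on this read-out higher numbers stand for weaker inhibition of growth and lower numbers for stronger inhibition of growth. Compound 1 `COc1ccc(C2=C(c3ccc(SC)cc3)CC3CCCN3C2=O)cc1C` gives 15000 nM, and compound 2 `CSc1ccc(C2=C(c3ccc(C)cc3)C(=O)N3CCCC3C2)cc1` gives 9000 nM. Going by the values given here, these two values lie within the scatter of each other, so compound 2 stands level with its only measured neighbour, and neither can be ranked above the other.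

The next analogue is compound 3 `CSc1ccc(C2=C(c3ccc(SC)cc3)C(=O)N3CCCC3C2)cc1`. It differs from compound 2 as follows: methylsulfanyl in place of methyl on an aromatic carbon. In words, methylsulfanyl stands in place of methyl on an aromatic carbon, para to a large group, turning 4-methylphenyl into 4-(methylsulfanyl)phenyl.

Among the compounds with values here, only one measured step bears on this change. That step, a 1.7-fold lower number from compound 1 to compound 2 (0.22 log units; within the scatter), altered the same aryl group, putting 4-methylphenyl in place of 4-methoxy-3-methylphenyl, and it stayed within the scatter. Within the data shown here, no measured pair exchanges methyl for methylsulfanyl directly, so the evidence is thin. No shift beyond the scatter is expected in this assay, and the estimated step is a 1.1-fold lower number from compound 2 to compound 3 (0.05 log units; within the scatter). Compound 3 is expected at about 8000 nM, with a likely range of 3000 nM to 25000 nM.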

Compound 3, concentration for 50% growth inhibition: 2000 nM
Estimate against measurement, compound 3: 4.0-fold (0.60 log units) above; the measured number lies below the stated range.
By their numbers in this assay, from the lowest: compound 3; then compounds 2 and 1 (each within the scatter of the next).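

In this assay, this position now yields a step that can be read: methylsulfanyl in place of methyl on an aromatic carbon, para to a large group, gives a 4.5-fold lower number from compound 2 to compound 3 (0.65 log units; beyond the scatter), whereas the earlier change to this aryl group, a 1.7-fold lower number from compound 1 to compound 2 (0.22 log units; within the scatter), stayed within the scatter. The step of a 7.5-fold lower number from compound 1 to compound 3 (0.88 log units; beyond the scatter) also lies beyond the scatter, so compound 3, which carries 4-(methylsulfanyl)phenyl on both of its aryl groups, stands apart from both neighbours as the strongest inhibitor of growth of the three. Nothing available explains why the added sulfur goes with this lower number.

The compounds shown leave open whether other groups at this place, such as an amine, a carboxylic acid or a longer chain like ethylsulfanyl, would match, exceed or lose the effect of methylsulfanyl. They also leave open whether the step depends on the 4-(methylsulfanyl)phenyl group already present on the other double-bonded ring carbon, and whether it would hold with a methoxy group or a halogen such as chlorine there instead.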